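A chloro group on the benzyl of compound 2

A few compounds are considered here, and "the series" means these few. Any claim that something is new, unique, unknown or untested is made for them only; others in the source may bear on it.

In a functional assay on a cell-free system (plasma, Oryctolagus cuniculus) for inhibition, with stated times of 5 min, 1 min and 6 min (a higher number here means a weaker inhibitor, a lower number a stronger inhibitor), compound 2 `CCOC(=O)c1c(C)nc(-c2cccc(C#N)c2)n1OCc1ccccc1` gives 5930 nM and compound 1 `CCOC(=O)COn1c(-c2cccc(C#N)c2)nc(C)c1C(=O)OCC` gives 6800 nM, two numbers within the scatter of each other. Compound 3 `CCOC(=O)c1c(C)nc(-c2cccc(C#N)c2)n1OCc1ccccc1Cl` has chloro in place of hydrogen on an aromatic carbon, turning benzyl into 2-chlorobenzyl: chloro in place of hydrogen on an aromatic carbon. Within the data shown here, the one measured step, a 1.1-fold lower number from compound 1 to compound 2 (0.06 log units; within the scatter), put phenyl in place of ethoxycarbonyl and stayed within the scatter. Among the measured compounds shown here, it is the only guide, and no measured compound carries a chloro, so no shift beyond the scatter is expected in this assay. The expected step is a 1.2-fold lower number from compound 2 to compound 3 (0.07 log units; within the scatter). Compound 3 is estimated at 5000 nM, within a range from 1800 nM to 13000 nM.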

Compound 3, half-maximal inhibitory concentration: 8710 nM
The estimate for compound 3 lay 1.7-fold (0.24 log units) below the measured number; measured number inside the range.
By their numbers in this assay, from the lowest: compounds 2, 1 and 3 (each within the scatter of the next).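

Chloro is the first group placed on the phenyl of the benzyl, on an aromatic carbon ortho to a large group. In this assay, that change gives (a 1.5-fold higher number from compound 2 to compound 3 (0.17 log units; within the scatter)), and the wider swap to 2-chlorobenzyl gives (a 1.3-fold higher number from compound 1 to compound 3 (0.11 log units; within the scatter)), so neither step can be read as a real change in inhibition. Nothing available explains these numbers. Still open, on these data alone, is whether a methoxy group or an amine on the same carbon, or chloro elsewhere on that phenyl, would shift the number beyond the scatter.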